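The source may hold more compounds than are shown below. What is called first, only, known or untested is meant among the compounds shown, and "the series" means these compounds.

Compound 1 `Cc1ccc(S(=O)(=O)N[C@H]2CCN(CCCOc3ccc(C(=O)C4CC4)cc3)C2)cc1` and compound 2 `O=C(c1ccc(OCCCN2CC[C@H](NS(=O)(=O)c3ccc(F)cc3)C2)cc1)C1CC1` share one core and differ only in a single group on an aromatic ring. In an assay on isolated protein for binding affinity to histamine H2 receptor (Homo sapiens) (on this read-out lower numbers stand for stronger inhibition and higher numbers for weaker inhibition), compound 1 gives 380 nM, and compound 2 gives 500 nM. The two numbers are within the usual scatter, so compound 1 stands no more than even with compound 2 in this assay; its number is simply the lower of the two.

Compound 3 `CC(C)(C)c1ccc(S(=O)(=O)N[C@H]2CCN(CCCOc3ccc(C(=O)C4CC4)cc3)C2)cc1` is not yet measured. The change from compound 1 to compound 3 is tert-butyl in place of methyl on an aromatic carbon. Among the compounds with values here, the only measured step that touches the same position is a 1.3-fold higher number from compound 1 to compound 2 (0.12 log units; within the scatter), which stayed within the scatter; that change was small, whereas the tert-butyl adds more heavy atoms, so the bearing is indirect. With nothing showing a shift at this place, no step beyond the scatter is expected in this assay, though the larger group leaves room for either direction. The expected step is a 1.3-fold higher number from compound 1 to compound 3 (0.12 log units; within the scatter). Compound 3 is therefore estimated at 500 nM, within a range from 150 nM to 1700 nM.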

Compound 3, inhibition constant: 730 nM
Estimate against measurement, compound 3: 1.5-fold (0.16 log units) below; the range from low to high includes it.
By their numbers in this assay, from the lowest: compounds 1, 2 and 3 (each within the scatter of the next).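

Even a much larger group is tolerated at this place on the ring in this assay: tert-butyl brings 4 heavy atoms where methyl has 1, yet the step is a 1.9-fold higher number from compound 1 to compound 3 (0.28 log units; within the scatter). Set against the fluoro group, tert-butyl gives a 1.5-fold higher number from compound 2 to compound 3 (0.16 log units; within the scatter), so all three groups tried here, methyl, fluoro and tert-butyl, sit within the scatter of one another, a stronger sign of a flat position than the small first step could give. No supporting measurement is at hand that would explain this flat reading.

Still open, going by these compounds, is whether a group of another kind at this place, such as an amine or a carboxylic acid, would move the number beyond the scatter. On these data alone, whether changes elsewhere on the shared core would do so also remains unknown.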